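Trimethoxyphenyl in Place of Hydroxyphenyl: Little Change Expected

A few compounds are considered here, and "the series" means these few. Any claim that something is new, unique, unknown or untested is made for them only; others in the source may bear on it.

Of the compounds shown here, three built on one shared core have been tested in a functional assay on 786-0 cells (Homo sapiens) for antiproliferative activity, with a stated time of 48 h; on this read-out lower numbers stand for stronger inhibition of growth and higher numbers for weaker inhibition of growth. Compound 1 `Cc1cc(O)c(C2=NN(c3ccc(S(N)(=O)=O)cc3)C(c3ccccc3O)C2)cc1Cl` gives 4210 nM in this assay, which is the lowest of the three numbers, although the other two fall within the usual scatter of it. Compound 2 `Cc1cc(O)c(C2=NN(c3ccc(S(N)(=O)=O)cc3)C(c3ccccc3Cl)C2)cc1Cl` gives 4520 nM in this assay, and compound 3 `COc1ccc(C2CC(c3cc(Cl)c(C)cc3O)=NN2c2ccc(S(N)(=O)=O)cc2)cc1OC` gives 5040 nM in this assay. The steps among them are all small: a 1.1-fold higher number from compound 1 to compound 2 (0.03 log units; within the scatter), a 1.2-fold higher number from compound 1 to compound 3 (0.08 log units; within the scatter) and a 1.1-fold higher number from compound 2 to compound 3 (0.05 log units; within the scatter).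

Compound 4 `COc1ccc(C2CC(c3cc(Cl)c(C)cc3O)=NN2c2ccc(S(N)(=O)=O)cc2)c(OC)c1OC` has not yet been measured. It differs from compound 1 in one place: 2,3,4-trimethoxyphenyl in place of 2-hydroxyphenyl on a saturated ring carbon. The measured step that bears most directly on this change is a 1.2-fold higher number from compound 1 to compound 3 (0.08 log units; within the scatter), where a 3,4-dimethoxyphenyl likewise replaced the 2-hydroxyphenyl on the saturated ring carbon and the number barely moved. The step of a 1.1-fold higher number from compound 2 to compound 3 (0.05 log units; within the scatter) points the same way, with a methoxy-bearing ring again giving a number close to its neighbour. Adding a third methoxy has no measured precedent here, so the expectation rests on these two steps alone.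

Compound 4 is therefore expected to give about 5200 nM in this assay, with a likely range from 2600 nM to 10500 nM. That estimate amounts to an expected step of a 1.2-fold higher number from compound 1 to compound 4 (0.09 log units; within the scatter), which would stay within the scatter.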

Compound 4, concentration for total growth inhibition: 4290 nM
Compound 4: middle estimate off by 1.2-fold (0.08 log units), on the high side; the range from low to high includes it.
By their numbers in this assay, from the lowest: compounds 1, 4, 2 and 3 (each within the scatter of the next).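

In this assay, the saturated ring carbon accepts a much larger group without the number leaving the scatter (a 1.0-fold higher number from compound 1 to compound 4 (0.01 log units; within the scatter)), even though the entering 2,3,4-trimethoxyphenyl has 12 heavy atoms against 7 in the 2-hydroxyphenyl, and 0 hydrogen-bond donors against 1. Adding a third methoxy to the ring also stays within the scatter (a 1.2-fold lower number from compound 3 to compound 4 (0.07 log units; within the scatter)), and so does the exchange of the 2-chlorophenyl for the 2,3,4-trimethoxyphenyl (a 1.1-fold lower number from compound 2 to compound 4 (0.02 log units; within the scatter)). Nothing available here offers an explanation for how flat these numbers are.

All four compounds carry a substituted phenyl ring at this carbon and all lie within the scatter of one another, so they do not show whether any group placed here can move the number beyond the scatter. Going by these compounds, it stays open whether a group of a different kind at this position, such as an amine, a carboxylic acid or a longer alkyl chain, would do so, and whether the same flatness would hold if the 4-sulfamoylphenyl group on the ring nitrogen were exchanged for another group.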